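Replacing 2-methylphenyl with 5-methylfuran-2-yl in compound 2

This account rests on a few compounds, and the source may have more. Where it says the series, first, only, none or still open, it means among the compounds named here.

- Compound 1 `Clc1ccc(-c2cc(-c3ccco3)nc(-c3cccs3)c2)o1` reads > 50000 nM as a limit
- Compound 2 `Cc1ccccc1-c1cc(-c2ccc(Cl)o2)cc(-c2ccsc2)n1` reads 4630 nM as a number
- Compound 3 `Clc1ccc(-c2cc(-c3ccoc3)cc(-c3ccsc3)n2)cc1` reads > 100000 nM as a limit

Within the data shown here, all three were tested in a functional assay on HCT-15 cells (Homo sapiens) for cytotoxicity, in the presence of a further agent that is not named here (a lower number here means a stronger inhibitor, a higher number a weaker inhibitor), and compound 2 gives 4630 nM as the only true number among them. The other two entries are limits of the assay, not numbers.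

Compound 4 `Cc1ccc(-c2cc(-c3ccc(Cl)o3)cc(-c3ccsc3)n2)o1` has not been measured yet. It keeps the 5-chlorofuran-2-yl and thiophen-3-yl groups of compound 2 and changes in one place only. There, 5-methylfuran-2-yl stands in place of 2-methylphenyl on an aromatic carbon next to the ring nitrogen (5-methylfuran-2-yl in place of 2-methylphenyl on an aromatic carbon).

Among the measured compounds shown here, no two measured compounds differ in just one place, so the expected size of this step rests on loose comparison. Compound 1 has no 2-methylphenyl group and remains a limit at > 50000 nM in this test. Compound 3 also has no such group and remains a limit at > 100000 nM in this test. Both also differ from compound 2 elsewhere, so this points only weakly towards a loss of strength.

The expected step is therefore a 3.2-fold higher number from compound 2 to compound 4 (0.51 log units; beyond the scatter) towards weaker inhibition. The estimated value of compound 4 is 15000 nM with an expected range of 4000 nM to 60000 nM in this test.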

Compound 4, half-maximal inhibitory concentration: > 50000 nM
Compound 4: only a limit was reported; the forecaster's own chance of this, stated with the estimate: 35%; at least 3.3-fold (0.52 log units) between middle value and limit.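

In this assay, among these compounds, exchanging 2-methylphenyl for 5-methylfuran-2-yl on the aromatic carbon next to the ring nitrogen gives an at least 10-fold higher number from compound 2 to compound 4 (1.03 log units; beyond the scatter), and this is the first comparison here in which only one place changes. Among the compounds shown here, it shows directly that this position is not indifferent to what sits on it: with the 5-chlorofuran-2-yl and thiophen-3-yl groups held constant, one aromatic ring exchanged for another is enough to lose the only true number in the set, so the earlier weak hint of a loss now rests on a matched pair. Compound 4 reads > 50000 nM, which is a limit of the assay and not a number, so the step gives a minimum size only, and it ends at a limit shared within this set: the limit of > 50000 nM in this assay, at which 2 of the 4 values shown sit.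

For the compounds shown here, the single pair cannot separate the loss of the six-membered carbon ring from the arrival of the ring oxygen or the changed placing of the methyl group. Going by these compounds, how a plain phenyl, a 2-aminophenyl or a 2-methoxyphenyl group would read at this carbon stays open, as does whether any group here can give a lower number than compound 2.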